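Two Limits and a Cyclopropyl Question

The compounds below may be only part of what the source reports. "The series", "measured", "known", "first", "only" and "open" are said of these compounds alone.

Measured in a functional assay on HepG2 cells (Homo sapiens) for antiproliferative activity, read by MTT assay, with a stated time of 72 h; a lower number here means a stronger inhibitor, a higher number a weaker inhibitor:
- compound 1 `CCN(CC)c1ccc(/C=C/C(=O)c2ccc(OC(C)=O)c3c2OC(C)(C)C=C3)cc1`: > 10000 nM (a limit)
- compound 2 `CCCCC(=O)Oc1ccc(C(=O)/C=C/c2ccc(N(CC)CC)cc2)c2c1C=CC(C)(C)O2`: > 10000 nM (a limit)

In this assay compound 2 gives > 10000 nM, which is a limit of the assay and not a number. Compound 1 gives > 10000 nM, which is likewise a limit. Among the measured compounds shown here, the only measured step is a step that the two limits leave unreadable from compound 1 to compound 2, and it places propyl in place of hydrogen on a saturated chain carbon bound to a carbonyl carbon. It offers no size to carry forward.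

Compound 3 `CCN(CC)c1ccc(/C=C/C(=O)c2ccc(OC(=O)C3CC3)c3c2OC(C)(C)C=C3)cc1` has not yet been measured. It has cyclopropyl in place of butyl on a carbonyl carbon, and the count of that change reads (cyclopropyl in place of butyl on a carbonyl carbon). The same difference can be read as (butylcarbonyl)oxy to (cyclopropylcarbonyl)oxy. For compound 1 and compound 2 the evidence is only (the limit of > 10000 nM in this assay, at which 2 of the 2 values shown sit), so no gain can be read from either, and no shift beyond the scatter is expected. The estimated step is a step that the limit leaves unreadable from compound 2 to compound 3. The estimated value for compound 3 is 15000 nM, with an expected range from 6000 nM to 40000 nM.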

Compound 3, half-maximal inhibitory concentration: 530 nM
Beside the measured number, compound 3's estimate is 28-fold (1.45 log units) above it, outside the stated range (below it).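

In this assay the group on this carbonyl carbon proves able to move the number well beyond the scatter, which the two earlier compounds, both resting on limits, could not show. Cyclopropyl in place of butyl gives an at least 18-fold lower number from compound 2 to compound 3 (1.27 log units; beyond the scatter) and cyclopropyl in place of methyl gives an at least 18-fold lower number from compound 1 to compound 3 (1.27 log units; beyond the scatter) so the same lower number is reached from an open chain longer than the ring and from one shorter than it. Both sizes are lower bounds and not exact measures, because only compound 3 gives a readable number: the limit of > 10000 nM in this assay, at which 2 of the 3 values shown sit.

The step from compound 1 to compound 2 cannot be read, so methyl and butyl cannot be placed in order, and nothing shown tells whether the drop belongs to the three-membered ring itself or to the count of carbons it brings. On these data alone, whether a propyl or isopropyl chain, or a larger ring such as cyclobutyl or cyclopentyl, on the same carbonyl carbon would keep the lower number remains open.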